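This account rests on a few compounds, and the source may have more. Where it says the series, first, only, none or still open, it means among the compounds named here.

Of the compounds shown here, three of one series have so far been measured in a physicochemical assay for solubility (a lower number here means a less soluble compound, a higher number a more soluble compound), and they spread widely. Compound 1 (`C[C@H](Oc1ccc(S(C)(=O)=O)cc1C(=O)N1Cc2ccc(C(F)(F)F)cc2C1)C(F)(F)F`) gives 1 ug/mL as the lowest of the three numbers. Compound 2 (`COc1cccc2c1CN(C(=O)c1cc(S(C)(=O)=O)ccc1O[C@@H](C)C(F)(F)F)C2`) gives 85 ug/mL and compound 3 (`C[C@H](Oc1ccc(S(C)(=O)=O)cc1C(=O)N1Cc2cnc(C(F)(F)F)cc2C1)C(F)(F)F`) gives 470 ug/mL in the same test, so both stand above compound 1 by well beyond the usual scatter of repeated measurements. The next compound to be tested is compound 4 (`C[C@H](Oc1ccc(S(C)(=O)=O)cc1C(=O)N1Cc2ccc(-c3ccncc3)cc2C1)C(F)(F)F`), which departs from compound 1 at one place: pyridin-4-yl in place of trifluoromethyl on an aromatic carbon. Among the measured compounds shown here, no measured pair shows this exchange, so its size in this assay cannot be read from the data and has to be judged. The judgement rests on the spread alone, since compound 3 at 470 ug/mL shows how far above compound 1 a close relative can lie. A rise beyond the scatter is therefore expected, and a 12-fold higher number from compound 1 to compound 4 (1.08 log units; beyond the scatter) is the estimated step, though with little support behind its size. For compound 4 the expected value is 12 ug/mL with an estimated range from 2 ug/mL to 70 ug/mL around it.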

Compound 4, solubility: 25 ug/mL
Estimate against measurement, compound 4: 2.1-fold (0.32 log units) below, and the stated range covers the measured number.
By their numbers in this assay, from the lowest: compound 1; then compound 4; then compound 2; then compound 3.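

In this assay, among the compounds shown here, pyridin-4-yl in place of trifluoromethyl on an aromatic carbon gives a 25-fold higher number from compound 1 to compound 4 (1.40 log units; beyond the scatter), the first step that can be read for a single change. It shows that this place, on a six-membered aromatic ring of carbon only, part of a fused or bridged system of two rings, is one where a single exchange can move the number by a large margin, and that a group of 6 heavy atoms with a ring of its own, entering for one of 4 heavy atoms with no ring, does not hold the number at the level of compound 1. Nothing measured in the material shown bears on what lies behind this step.

From the compounds shown here alone, whether the step belongs to the ring nitrogen of pyridin-4-yl or to the aromatic ring as a whole stays open, and a phenyl group at this place would separate the two. Also open, going by these compounds, is how an amine such as morpholin-4-yl or a carboxylic acid would stand at the same carbon on the core of compound 1.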